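Swapping Chloro for Bromo in Cell Growth Inhibitors

The source may report more compounds than this note shows. Statements on the series, on what has been measured and on what is new or still open speak of the compounds shown alone.

Compound 1 `COc1ccc(CN(C(=O)CSC(=S)N2CCN(C(=O)OC(C)(C)C)CC2)c2ccc(Cl)cc2)cc1` and compound 2 `COc1ccc(CN(C(=O)CSC(=S)N2CCN(C(=O)OC(C)(C)C)CC2)c2ccc(Br)cc2)cc1` share one core, while compound 3 `COc1cc(N(Cc2ccc(Cl)cc2)C(=O)CSC(=S)N2CCN(C(=O)OC(C)(C)C)CC2)cc(OC)c1OC` carries another; the difference between the two cores is not broken down here. In a functional assay on HCT-116 cells (Homo sapiens) for inhibition, read by CCK-8 assay, with a stated time of 48 h (a higher number here means a weaker inhibitor, a lower number a stronger inhibitor), compound 1 reaches only a limit, > 20000 nM. Compound 2 likewise gives only a limit in this assay, > 20000 nM. Compound 3 gives a number in this assay, 8490 nM. The change from compound 1 to compound 2 is bromo in place of chloro on an aromatic carbon, and its step is a step that the two limits leave unreadable from compound 1 to compound 2 because both values rest on (the limit of > 20000 nM in this assay, at which 2 of the 3 values shown sit). Compound 4 `COc1cc(N(Cc2ccc(Br)cc2)C(=O)CSC(=S)N2CCN(C(=O)OC(C)(C)C)CC2)cc(OC)c1OC` is not yet measured and differs from compound 3 by bromo in place of chloro on an aromatic carbon, the same change. Among the compounds with values here, the step from compound 3 to compound 4 is expected to be a 1.1-fold lower number from compound 3 to compound 4 (0.03 log units; within the scatter), small, since the measured pair leaves no readable size and the only anchor is compound 3 at 8490 nM. Compound 4 is therefore expected to give about 8000 nM, most likely between 3500 nM and 19000 nM.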

Compound 4, half-maximal inhibitory concentration: 11400 nM
For compound 4 the middle estimate is 1.4-fold (0.15 log units) below the measured one; measured number inside the range.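

On the core of compound 3, bromo in place of chloro gives a 1.3-fold higher number from compound 3 to compound 4 (0.13 log units; within the scatter) in this assay, so on this core the swap makes no difference that can be told from ordinary assay scatter. The same swap on the core of compound 1 cannot be read, because compound 1 and compound 2 both give a limit and not a number: the limit of > 20000 nM in this assay, at which 2 of the 4 values shown sit. The result therefore describes the swap on one core only and does not show that its size carries from one core to another.

Still open, going by these compounds, is how a nitrile or an amine would read in place of the halogen on the 4-chlorobenzyl group. Also open, on these data alone, is how the swap would read on a third core.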